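This account rests on a few compounds, and the source may have more. Where it says the series, first, only, none or still open, it means among the compounds named here.

Compounds measured so far:
compound 1, `C#CCn1cc(C(=O)NCCCOC(=O)CNC(=O)OC(C)(C)C)c(=O)c2cccnc21`: 9000 nM
compound 2, `C#CCn1cc(C(=O)NCCCOC(=O)[C@H]2OC(C)(C)N(C(=O)OC(C)(C)C)[C@@H]2c2ccccc2)c(=O)c2ccc(Cl)nc21`: 6000 nM
compound 3, `C#CCn1cc(C(=O)NCCCOC(=O)[C@H]2CCCN2C(=O)OC(C)(C)C)c(=O)c2ccc(Cl)nc21`: > 10000 nM

In a functional assay on PA-1 cells (Homo sapiens) for cytotoxicity, read by MTT assay, with a stated time of 72 h (a higher number here means a weaker inhibitor, a lower number a stronger inhibitor), compound 1 gives 9000 nM and compound 2 gives 6000 nM; the two values lie within the scatter of each other. For compound 3 the assay reports only a limit, > 10000 nM, which is the limit of > 10000 nM in this assay, at which 1 of the 3 values shown sits. Among the measured compounds shown here, compound 3 therefore stands at the top of the measured range, with no number of its own, and no measured pair of compounds differs in only one place, so no measured step guides the next move.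

The step to compound 4, `C#CCn1cc(C(=O)NCCCOC(=O)[C@H](C)NC(=O)OC(C)(C)C)c(=O)c2ccc(Cl)nc21`, is 1-((tert-butoxycarbonyl)amino)ethyl in place of 1-(tert-butoxycarbonyl)pyrrolidin-2-yl on a carbonyl carbon. Compound 1 and compound 2 carry tert-butoxycarbonyl-protected amino acid esters on the same carbonyl carbon and both give weak but measurable values, so the change from compound 3 to compound 4 is expected to bring the number just inside the measurable range, by a step of an at least 1.1-fold lower number from compound 3 to compound 4 (0.04 log units; that floor lies within the scatter), or none beyond the scatter. In this assay compound 4 is expected to give 9000 nM, with a range from 4000 nM to 20000 nM.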

Compound 4, half-maximal inhibitory concentration: > 10000 nM
Compound 4: a limit, no number; the forecaster's own chance of this, stated with the estimate: 40%; at least 1.1-fold (0.04 log units) between middle value and limit.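

In this assay compound 4 gives > 10000 nM as a limit and not a number. Among the compounds shown here, compound 3 also carries only a limit, so no step between compound 3 and compound 4 can be read: the limit of > 10000 nM in this assay, at which 2 of the 4 values shown sit. The compounds shown leave open whether 1-((tert-butoxycarbonyl)amino)ethyl in place of 1-(tert-butoxycarbonyl)pyrrolidin-2-yl changes the value at all.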